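The source may hold more compounds than are shown below. What is called first, only, known or untested is meant among the compounds shown, and "the series" means these compounds.

Working notes on the series built on the shared core. Compound 1 `CCOc1ccc(-c2cc(=O)c3c(o2)C(CC)(CC)C(=O)C(CC)=C3O)cc1` and compound 2 `CCC1=C(O)c2c(oc(-c3ccccc3C(F)(F)F)cc2=O)C(CC)(CC)C1=O` differ only in the aryl group attached to that core. In a functional assay on KB cells (Homo sapiens) for antiproliferative activity, read by sulforhodamine B assay, with a stated time of 3 days (a lower number here means that less compound is needed, a higher number that more compound is needed for the effect), compound 1 gives only a limit, > 52.4 uM. Compound 2 gives a number in this assay, 45.6 uM. Among the measured compounds shown here, compound 1 therefore stands at the edge of what this assay resolves: the limit of > 52.4 uM in this assay, at which 1 of the 2 values shown sits, so no measured step from compound 1 to any other compound is available, and nothing can be said of its order relative to compound 2 beyond the fact that one value is a limit and the other a number close to it.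

Compound 3 `CCC1=C(O)c2c(oc(-c3ccc(C)c(Cl)c3)cc2=O)C(CC)(CC)C1=O` is the next member to be measured in this assay. It differs from compound 1 by 3-chloro-4-methylphenyl in place of 4-ethoxyphenyl on an aromatic carbon. Since compound 1 is known only as a limit, the change from compound 1 to compound 3 is expected to amount to nothing beyond the usual scatter, an at least 1.0-fold lower number from compound 1 to compound 3 (0.02 log units; that floor lies within the scatter), with the value of compound 3 resting near the limit. Compound 3 is accordingly estimated at 50 uM, within a range from 20 uM to 120 uM.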

Compound 3, concentration for half-maximal effect: 39 uM
Beside the measured number, compound 3's estimate is 1.3-fold (0.11 log units) above it; the measured number falls inside the stated range.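

In this assay, 3-chloro-4-methylphenyl in place of 4-ethoxyphenyl on this aromatic carbon, next to the ring oxygen, gives an at least 1.3-fold lower number from compound 1 to compound 3 (0.12 log units; that floor lies within the scatter), so this change cannot be claimed as a real gain. Compound 3 adds a second aryl group at this position that returns a number rather than a limit, 39 uM, and it does so with a chlorine and a methyl group on the ring where compound 1 carries an ethoxy group. The true size of the step remains unknown, since the value for compound 1 is only a limit: the limit of > 52.4 uM in this assay, at which 1 of the 3 values shown sits.

As far as these compounds go, it remains open whether any group on this aromatic carbon can move the number well clear of the values seen here, for example a phenyl ring bearing an amine or a carboxylic acid, or one bearing a longer chain such as butoxy in place of ethoxy. Also open, from the compounds shown here alone, is what the chlorine and the methyl group each contribute, as they enter together in compound 3.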